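Dichlorophenyl swap on a cinnamamide series

The source may report more compounds than this note shows. Statements on the series, on what has been measured and on what is new or still open speak of the compounds shown alone.

Measured in a functional assay on A549 cells (Homo sapiens) for antiproliferative activity, read by MTT assay, with a stated time of 48 h; on this read-out lower numbers stand for stronger inhibition and higher numbers for weaker inhibition:
compound 1, `COc1ccc(/C=C/C(=O)Nc2cc3c(Nc4ccc(Cl)c(Cl)c4)ncnc3s2)cc1`, 3320 nM
compound 2, `COc1ccc(/C=C/C(=O)Nc2cc3c(Nc4cc(Cl)cc(Cl)c4)ncnc3s2)cc1`, 21900 nM
compound 3, `O=C(/C=C/c1ccccc1)Nc1cc2ncnc(Nc3cc(Cl)cc(Cl)c3)c2s1`, 12500 nM

Compound 4, `O=C(/C=C/c1ccccc1)Nc1cc2ncnc(Nc3ccc(Cl)c(Cl)c3)c2s1`, is not yet measured in this assay. The change from compound 3 to compound 4 is 3,4-dichlorophenyl in place of 3,5-dichlorophenyl on a nitrogen on an aromatic ring. The same change is already seen from compound 2 to compound 1, (3,4-dichlorophenyl in place of 3,5-dichlorophenyl on a nitrogen on an aromatic ring), where it gave a 6.6-fold lower number from compound 2 to compound 1 (0.82 log units; beyond the scatter). How the core of compound 3 differs from that of compound 2 is not broken down here; the values of compound 3 and compound 2 lie within the usual scatter of each other. Going by the values given here, with only one earlier instance of this change, the expectation for compound 4 rests on that single step, and a step of similar size is expected, a 6.3-fold lower number from compound 3 to compound 4 (0.80 log units; beyond the scatter). Compound 4 is therefore expected near 2000 nM, within a range of 800 nM to 5500 nM.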

Compound 4, half-maximal inhibitory concentration: 19500 nM
The estimate for compound 4 lay 9.8-fold (0.99 log units) below the measured number, and the stated range ends below it.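

In this assay, 3,4-dichlorophenyl in place of 3,5-dichlorophenyl gives a 1.6-fold higher number from compound 3 to compound 4 (0.19 log units; within the scatter), so the gain seen on the core of compound 1 does not reappear on the core of compound 4. The two steps disagree: the same change on two cores in this assay, a 6.6-fold lower number (0.82 log units; beyond the scatter) from compound 2 to compound 1 and a 1.6-fold higher number (0.19 log units; within the scatter) from compound 3 to compound 4, 10-fold (1.01 log units) apart, beyond the scatter of two such steps. This change therefore cannot be carried between these two cores as a fixed step, but the data do not show which feature of the cores separates the outcomes, and with one pair per core neither step can be taken as general.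

Still open, going by these compounds, is how the change behaves on further cores. Also open, on these data alone, is how a 3-chloro-4-fluorophenyl group on that nitrogen would read on either core.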